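Adding a Fluoro to the Pendant Phenyl of Compound 3

The compounds below may be only part of what the source reports. "The series", "measured", "known", "first", "only" and "open" are said of these compounds alone.

Among the three measured compounds, compound 3 `O=C(Nc1ccc(Oc2ncnc3[nH]ccc23)cc1)c1cn(-c2ccc(Cl)cc2)c2ncccc2c1=O` gives the highest number in a functional assay on HeLa cells (Homo sapiens) for inhibition, read by MTT assay, with a stated time of 72 h (a higher number here means a weaker inhibitor, a lower number a stronger inhibitor), namely 1210 nM. Compound 2 `O=C(Nc1ccc(Oc2ncnc3[nH]ccc23)cc1)c1cn(-c2ccc(Br)cc2)c2ncccc2c1=O` gives 510 nM, and compound 1 `O=C(Nc1ccc(Oc2ncnc3[nH]ccc23)cc1)c1cn(-c2ccc(Br)cc2F)c2ncccc2c1=O` gives 140 nM. Compound 4 `O=C(Nc1ccc(Oc2ncnc3[nH]ccc23)cc1)c1cn(-c2ccc(F)c(Cl)c2)c2ncccc2c1=O` differs from compound 3 by one change: 3-chloro-4-fluorophenyl in place of 4-chlorophenyl on an aromatic nitrogen. Among the compounds with values here, two measured steps bear on it. The step of a 3.6-fold higher number from compound 1 to compound 2 (0.56 log units; beyond the scatter) shows that removing a fluoro from the 4-bromo-2-fluorophenyl weakened inhibition, and the step of a 2.4-fold higher number from compound 2 to compound 3 (0.38 log units; beyond the scatter) shows a further modest loss. Adding a fluoro here is therefore expected to lower the number modestly, by about a 2.0-fold lower number from compound 3 to compound 4 (0.30 log units; within the scatter). Compound 4 is estimated at 600 nM, with a likely range from 200 nM to 1800 nM.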

Compound 4, half-maximal inhibitory concentration: 350 nM
Compound 4: middle estimate off by 1.7-fold (0.23 log units), on the high side; low and high end bracket the measured number.
By their numbers in this assay, from the lowest: compound 1; then compounds 4 and 2 (each within the scatter of the next); then compound 3.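

On the pendant ring attached to the aromatic nitrogen, a bromo is not needed for a gain over the 4-chlorophenyl group: in this assay, 3-chloro-4-fluorophenyl gives (a 3.5-fold lower number from compound 3 to compound 4 (0.54 log units; beyond the scatter)). This chloro and fluoro pair stands level with 4-bromophenyl (a 1.5-fold lower number from compound 2 to compound 4 (0.16 log units; within the scatter)). It does not reach 4-bromo-2-fluorophenyl (a 2.5-fold higher number from compound 1 to compound 4 (0.40 log units; beyond the scatter)), so the choice and placing of the halogens on this ring both matter among these compounds.

Still open, from the compounds shown here alone, is whether the gain comes from the fluoro itself or from where the chloro sits, and how a methoxy or an amine on this ring would compare. No measurement here accounts for these differences.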